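The source may report more compounds than this note shows. Statements on the series, on what has been measured and on what is new or still open speak of the compounds shown alone.

Measured so far:
compound 1 `O=C(/C=C\Nc1ccc(Cl)cc1)c1cn(-c2ccccc2)nc1-c1ccc(F)cc1` with 4600 nM
compound 2 `COc1ccc(-c2nn(-c3ccccc3)cc2C(=O)/C=C\Nc2cc(OC)c(OC)c(OC)c2)cc1` with 14600 nM
compound 3 `COc1cc(-c2nn(-c3ccccc3)cc2C(=O)/C=C\Nc2ccc(Cl)cc2)cc(OC)c1OC` with 7680 nM

All three share a core in which a pyrazole carries a phenyl group and an aryl group, and is joined through a carbonyl and a short unsaturated chain to an amine nitrogen bearing a second aryl group. Their readings in a functional assay on HT-29 cells (Homo sapiens) for antiproliferative activity, read by MTT assay, with a stated time of 48 h (on this read-out higher numbers stand for weaker inhibition and lower numbers for stronger inhibition), sit close together. Compound 3 has the second highest of the three numbers; its nearest neighbour is compound 1, and the gap between them lies within the scatter, as does the gap to compound 2, so no ordering among the three can be claimed.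

Compound 4 `COc1cc(N/C=C\C(=O)c2cn(-c3ccccc3)nc2-c2cc(OC)c(OC)c(OC)c2)cc(OC)c1OC` has not yet been measured. The change from compound 3 is 3,4,5-trimethoxyphenyl in place of 4-chlorophenyl on an amine nitrogen, so compound 4 carries a 3,4,5-trimethoxyphenyl group at both ends of the core. Going by the values given here, no pair of measured compounds differs in this one place alone, so the size of this step is not known from the data. Because compound 3 gives 7680 nM and its gaps to the other two measured values in this assay lie within the scatter, the step from compound 3 to compound 4 is expected to be small, a 1.3-fold higher number from compound 3 to compound 4 (0.11 log units; within the scatter), with no clear direction beyond the scatter. Compound 4 is estimated at 10000 nM, within a range from 3000 nM to 35000 nM.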

Compound 4, half-maximal inhibitory concentration: 8400 nM
The estimate for compound 4 lay 1.2-fold (0.08 log units) above the measured number; measured number inside the range.
By their numbers in this assay, from the lowest: compounds 1, 3, 4 and 2 (each within the scatter of the next, the first and the last beyond it).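

In this assay, going by these compounds alone, putting 3,4,5-trimethoxyphenyl in place of 4-chlorophenyl on an amine nitrogen gives a 1.1-fold higher number from compound 3 to compound 4 (0.04 log units; within the scatter), the first direct reading of a change at this place. The two groups cannot be told apart here, even though the entering group is the larger by heavy atoms and brings hydrogen-bond acceptors that 4-chlorophenyl lacks, and a second place behaves alike: 3,4,5-trimethoxyphenyl in place of 4-methoxyphenyl on an aromatic carbon gives a 1.7-fold lower number from compound 2 to compound 4 (0.24 log units; within the scatter) in this assay. No further measurement is at hand to explain why neither change moves the number beyond the scatter.

Going by these compounds, both steps exchange one substituted phenyl group for another, so it remains open whether something of a different kind on the amine nitrogen, such as a methyl or a cyclohexyl group, or a carboxylic acid or an amine on the aryl ring, would shift the number beyond the scatter. On these data alone, what happens when the unsubstituted phenyl group on the shared core is replaced, for instance by a pyridine ring, also remains open.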